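Moving one methyl group at the limit of the assay

A few compounds are considered here, and "the series" means these few. Any claim that something is new, unique, unknown or untested is made for them only; others in the source may bear on it.

Measured so far in a functional assay on COLO 205 cells (Homo sapiens) for cytotoxicity, read by MTT assay, with a stated time of 48 h; on this read-out higher numbers stand for weaker inhibition and lower numbers for stronger inhibition
- Compound 1 `Fc1cccc(-c2nc(Nc3cccc(Cl)c3)c3cc(F)ccc3n2)c1` gives > 50000 nM as a limit
- Compound 2 `Fc1cccc(-c2nc(Nc3cccc(Br)c3)c3cc(F)ccc3n2)c1` gives > 50000 nM as a limit
- Compound 3 `Cc1cccc(Nc2nc(-c3cccc(F)c3)nc3ccc(F)cc23)c1` gives > 50000 nM as a limit

Compound 3 has no exact number, only the limit > 50000 nM in this record. All three compounds share this position (the limit of > 50000 nM in this assay, at which 3 of the 3 values shown sit). Compound 4 `Cc1ccccc1Nc1nc(-c2cccc(F)c2)nc2ccc(F)cc12` differs from compound 3 by one change (2-methylphenyl in place of 3-methylphenyl on a nitrogen on an aromatic ring) that puts 2-methylphenyl in place of 3-methylphenyl on a nitrogen on an aromatic ring. For the measured compounds named here, three measured steps bear on it as swaps of one group (a step that the two limits leave unreadable from compound 1 to compound 2; a step that the two limits leave unreadable from compound 1 to compound 3; a step that the two limits leave unreadable from compound 2 to compound 3) and none has a readable size. No change beyond the scatter is therefore expected in this assay and the expected step is a number no higher from compound 3 to compound 4 (the limit leaves the size open) for now. Compound 4 is estimated at 50000 nM with an expected range from 25000 nM to 100000 nM and will probably also be reported as a limit.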

Compound 4, half-maximal inhibitory concentration: > 50000 nM
Compound 4: no number, only a limit; the forecaster's own chance of this, stated with the estimate: 85%; the middle value sits exactly at the limit.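

No step among compound 1, compound 2, compound 3 and compound 4 can be read, since each gives only a limit: the limit of > 50000 nM in this assay, at which 4 of the 4 values shown sit.

The compounds shown leave open how these four truly compare in this assay, including whether 2-methylphenyl and 3-methylphenyl differ at all.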